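A few compounds are considered here, and "the series" means these few. Any claim that something is new, unique, unknown or untested is made for them only; others in the source may bear on it.

In an ADME assay on microsomes from liver (Rattus norvegicus) for metabolic stability (on this read-out lower numbers stand for a shorter-lived compound and higher numbers for a longer-lived compound), compound 1 `COc1cc(OCc2cccc(-c3cnc(OC)nc3)c2)c2cc(-c3cn4nc(OC)sc4n3)oc2c1` gives 1.03 h, while compound 2 `COc1cc(OCc2cccc(-c3cncnc3)c2)c2cc(-c3cn4nc(OC)sc4n3)oc2c1` gives 0.117 h, the lower of the two numbers, with an 8.8-fold lower number from compound 1 to compound 2 (0.94 log units; beyond the scatter) separating them. Compound 3 `COc1ccc(-c2cccc(COc3cc(OC)cc4oc(-c5cn6nc(OC)sc6n5)cc34)c2)nc1` arises from compound 2 by 5-methoxypyridin-2-yl in place of pyrimidin-5-yl on an aromatic carbon. Among the measured compounds shown here, the one measured step bears on this only in part: that step removed a methoxy and gave a large drop, and here a methoxy returns on a changed ring. Compound 3 is therefore expected to sit higher in this assay, by a 3.4-fold higher number from compound 2 to compound 3 (0.53 log units; beyond the scatter). The estimated half-life of compound 3 is 0.4 h, within a range from 0.12 h to 1.3 h.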

Compound 3, half-life: 0.317 h
Beside the measured number, compound 3's estimate is 1.3-fold (0.10 log units) above it; measured number inside the range.
By their numbers in this assay, from the lowest: compound 2; then compound 3; then compound 1.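

Read in this assay, a methoxy on a different ring restores only part of the half-life: there is a 2.7-fold higher number from compound 2 to compound 3 (0.43 log units; beyond the scatter), yet still a 3.2-fold lower number from compound 1 to compound 3 (0.51 log units; beyond the scatter). At this aromatic carbon, then, the methoxy alone does not set the number; 5-methoxypyridin-2-yl and the 2-methoxypyrimidin-5-yl of compound 1 carry the same group and still differ beyond the scatter. No measurement at hand accounts for this gap. Open, as far as these compounds go, is whether an amine or a fluorine in place of that methoxy on the pyrimidin-5-yl ring would hold the half-life of compound 1.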